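This account rests on a few compounds, and the source may have more. Where it says the series, first, only, none or still open, it means among the compounds named here.

Measured so far:
compound 1 `CC(=O)Nc1ccc(CNc2cc(Br)cc3[nH]ncc23)cc1`: 48%
compound 2 `Nc1cccc(CNc2cc(Br)cc3[nH]ncc23)c1`: 31%

In an assay for inhibition of Indoleamine 2,3-dioxygenase 1 (Homo sapiens), with a stated time of 1 h, tested at 10 uM (a higher number here means more inhibition at the concentration tested (going by the name of the read-out), a lower number less inhibition), compound 1 gives 48%, the higher of the two numbers. Compound 2 gives 31%, which lies beyond the usual scatter below compound 1. Within the data shown here, no pair of measured compounds differs in a single place, so no step size is established. Compound 3 `NS(=O)(=O)c1ccc(CNc2cc(Br)cc3[nH]ncc23)cc1` differs from compound 1 by sulfamoyl in place of acetamido on an aromatic carbon. The expected step of a number 8 percentage points lower from compound 1 to compound 3 (within the scatter) is small, without a settled direction, and may well stay within the scatter. Compound 3 is estimated at 40%, with a range from 15% to 65%.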

Compound 3, a percentage reported as inhibition, at one concentration (the size of the read-out at that concentration, not a potency): 20%
Compound 3: the middle estimate sits 20 percentage points above what was measured, within the range that was stated.
By their numbers in this assay, from the lowest: compound 3; then compound 2; then compound 1.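

In this assay, sulfamoyl in place of acetamido on an aromatic carbon, para to a large group, gives a number 28 percentage points lower from compound 1 to compound 3 (beyond the scatter). Among these compounds, this is the first single-place step, and it shows that the read-out at this position responds to the choice between these two groups, even though they match in heavy-atom count and carry no net charge. No measurement here bears on the origin of this step. Going by these compounds, how an amine, a carboxylic acid or a longer acyl chain would read at this position remains open. On these data alone, whether the step holds with other changes to the shared core also remains open.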